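The source may report more compounds than this note shows. Statements on the series, on what has been measured and on what is new or still open speak of the compounds shown alone.

Measured so far in a functional assay on the whole organism for inhibition, with Rattus norvegicus as the target, read by paw edema, at a dose of 100 mg/kg by the oral route; on this read-out lower numbers stand for less inhibition and higher numbers for more inhibition at the one dose given (going by the name of the read-out):
compound 1, `CCOC(=O)c1c(O)c2cccnc2n(-c2ccccc2)c1=O`: 23.5%
compound 2, `CNC(=O)c1c(O)c2cccnc2n(-c2ccccc2)c1=O`: 9.6%
compound 3, `CN(C)CCNC(=O)c1c(O)c2cccnc2n(-c2ccccc2)c1=O`: 22.6%

Compound 2 stands lowest of these three. Its nearest neighbour is compound 3, reached by a number 13 percentage points higher from compound 2 to compound 3 (beyond the scatter); the furthest is compound 1, from which compound 2 is reached by a number 13.9 percentage points lower from compound 1 to compound 2 (beyond the scatter). Both steps alter only the group on the carbonyl carbon or on the amide-type nitrogen, and both lie beyond the scatter.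

Compound 4, `O=C(Nc1nccs1)c1c(O)c2cccnc2n(-c2ccccc2)c1=O`, has not yet been measured. It differs from compound 2 as follows: 1,3-thiazol-2-yl in place of methyl on an amide-type nitrogen. Within the data shown here, the step bearing most directly on this change is the one from compound 2 to compound 3, where a larger group on the amide-type nitrogen brought a modest rise; the step from compound 1 to compound 2 shows that the methylamino compound sits low among the three. A modest rise is therefore expected, as a number 11.4 percentage points higher from compound 2 to compound 4 (beyond the scatter). For compound 4 the estimate is 21%. For compound 4 the expected range runs from 8% to 36%.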

Compound 4, a percentage reported as inhibition, in the whole organism at one dose (the size of the read-out at that dose, not a potency): 4.6%
Beside the measured number, compound 4's estimate is 16.4 percentage points above it; measured number outside the range, below it.
By their numbers in this assay, from the lowest: compounds 4 and 2 (each within the scatter of the next); then compounds 3 and 1 (each within the scatter of the next).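

In this assay, a larger group on the amide-type nitrogen does not by itself raise the number: 1,3-thiazol-2-yl in place of methyl gives a number 5 percentage points lower from compound 2 to compound 4 (within the scatter), so compound 2 and compound 4 cannot be told apart, although 2-(dimethylamino)ethyl in place of the same methyl gave a number 13 percentage points higher from compound 2 to compound 3 (beyond the scatter). Against the two compounds at the higher end, the change gives a number 18 percentage points lower from compound 3 to compound 4 (beyond the scatter) and a number 18.9 percentage points lower from compound 1 to compound 4 (beyond the scatter), which places the 1,3-thiazol-2-yl amide with the methyl amide at the low end of the four. Nothing measured here accounts for this difference between the groups on that nitrogen.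

The compounds shown leave open whether a pyridyl ring on the same nitrogen would also stay at the low end. They also leave open whether a morpholine at the end of the ethyl chain would match the dimethylamino group.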